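The compounds below may be only part of what the source reports. "The series", "measured", "known", "first", "only" and "open" are said of these compounds alone.

All three measured compounds were tested in a functional assay on B16 cells (Mus musculus) for antiproliferative activity, read by MTT assay, with a stated time of 24 h; a lower number here means a stronger inhibitor, a higher number a weaker inhibitor; the numbers so far are:

Compound 1 `C#CCOc1ccc2c(=O)c(-c3cc(OC)c(OC)cc3OC)coc2c1` gives 4500 nM in this assay.
Compound 2 `COc1cc(OC)c(-c2coc3cc(OCc4ccccc4F)ccc3c2=O)cc1OC` gives 1610 nM in this assay.
Compound 3 `COc1cc(OC)c(-c2coc3cc(OCc4cccc(F)c4)ccc3c2=O)cc1OC` gives 2440 nM in this assay.

Compound 2 sits at the low end of these three numbers. Its separation from compound 1 a 2.8-fold lower number from compound 1 to compound 2 (0.45 log units; beyond the scatter) lies beyond the scatter, whereas the step of a 1.5-fold higher number from compound 2 to compound 3 (0.18 log units; within the scatter) is within it, so compound 2 and compound 3 cannot be told apart on these data.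

Compound 4 `COc1cc(OC)c(-c2coc3cc(OCc4cccc(Br)c4)ccc3c2=O)cc1OC` has not yet been measured. It differs from compound 2 in one place: 3-bromophenyl in place of 2-fluorophenyl on a saturated chain carbon bound to an oxygen on an aromatic ring. Of the measured steps, only a 1.5-fold higher number from compound 2 to compound 3 (0.18 log units; within the scatter) bears on this change, since it also moves a halogen on the benzyl ring from the 2- to the 3-position; that step was within the scatter. Among the measured compounds shown here, no measured pair shows what exchanging fluorine for bromine does, so that part of the change has no support in the data.

Compound 4 is therefore expected to land close to compound 2 and compound 3, with a step of a 1.3-fold higher number from compound 2 to compound 4 (0.12 log units; within the scatter) that is not expected to exceed the scatter. The estimate for compound 4 in this assay is 2100 nM, within a range from 900 nM to 5000 nM.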

Compound 4, half-maximal inhibitory concentration: 4400 nM
Compound 4: the middle estimate sits 2.1-fold (0.32 log units) below what was measured; low and high end bracket the measured number.
By their numbers in this assay, from the lowest: compounds 2, 3, 4 and 1 (each within the scatter of the next, the first and the last beyond it).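

In this assay, the change from 2-fluorobenzyl to 3-bromobenzyl on this oxygen gives a step that goes beyond the scatter (a 2.7-fold higher number from compound 2 to compound 4 (0.44 log units; beyond the scatter)), but it alters both the halogen and its place on the ring, so it cannot be credited to either one alone. Among the compounds shown here, the pair that differs only in the halogen gives the first direct look at bromo in place of fluoro on an aromatic carbon, and that step stays within the scatter (a 1.8-fold higher number from compound 3 to compound 4 (0.26 log units; within the scatter)), so this exchange alone cannot be told from no change. The 3-bromobenzyl compound also cannot be told apart from the ethynyl compound (a 1.0-fold lower number from compound 1 to compound 4 (0.01 log units; within the scatter)), which means a halogenated benzyl group at this place does not by itself set a compound apart from that one, and no measurement at hand gives a reason for any of these steps.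

The compounds shown leave open what 2-bromobenzyl would give, which would separate the effect of the halogen from that of its place on the ring. They also leave open whether an amine or a nitrile on this ring, or a longer chain carrying the ring, would move the number beyond the scatter.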